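Pyridin-4-yl for pyridin-3-yl: one swap in two contexts

The source may report more compounds than this note shows. Statements on the series, on what has been measured and on what is new or still open speak of the compounds shown alone.

Compound 1 `O=C(/C=C/c1cn(-c2ccccc2)nc1-c1cccnc1)c1ccccc1` gives 2000 nM in a functional assay on HCT-116 cells (Homo sapiens) for inhibition, read by sulforhodamine B assay, with a stated time of 72 h; on this read-out lower numbers stand for stronger inhibition and higher numbers for weaker inhibition. Compound 3 `O=C(/C=C/c1cn(-c2ccccc2)nc1-c1ccncc1)c1ccccc1` carries pyridin-4-yl in place of pyridin-3-yl on an aromatic carbon and gives 3100 nM; the step is a 1.6-fold higher number from compound 1 to compound 3 (0.19 log units; within the scatter). Compound 2 `COc1ccc(C(=O)/C=C/c2cn(-c3ccccc3)nc2-c2cccnc2)c(OC)c1OC` gives 1100 nM; the difference between the core of compound 2 and that of compound 1 is not broken down here. Compound 2 holds the lowest of the three numbers, but its value and that of compound 1 lie within the scatter of each other, while compound 3 sits higher than compound 2 beyond the scatter. Compound 4 `COc1ccc(C(=O)/C=C/c2cn(-c3ccccc3)nc2-c2ccncc2)c(OC)c1OC` is not yet measured; it differs from compound 2 by pyridin-4-yl in place of pyridin-3-yl on an aromatic carbon, the same change at the same place as between compound 1 and compound 3. Among the compounds with values here, a step of a 1.6-fold higher number from compound 2 to compound 4 (0.21 log units; within the scatter) is expected, resting on the single prior instance a 1.6-fold higher number from compound 1 to compound 3 (0.19 log units; within the scatter). Compound 4 is therefore estimated at 1800 nM, with a likely range from 900 nM to 3600 nM.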

Compound 4, half-maximal inhibitory concentration: 1300 nM
Estimate against measurement, compound 4: 1.4-fold (0.14 log units) above; measured number inside the range.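

The swap of pyridin-3-yl for pyridin-4-yl on the core of compound 2 gives a 1.2-fold higher number from compound 2 to compound 4 (0.07 log units; within the scatter) in this assay. Set beside the earlier step, the two cores agree: the same change on two cores in this assay, a 1.6-fold higher number (0.19 log units; within the scatter) from compound 1 to compound 3 and a 1.2-fold higher number (0.07 log units; within the scatter) from compound 2 to compound 4, 1.3-fold (0.12 log units) apart, within the scatter of two such steps. Within the data shown here, with both steps inside the scatter, this shows only that the swap leaves no readable mark on these two cores; it does not establish a real direction or size for the effect, and two cores cannot support a rule for others.

Still open, on these data alone, is how pyridin-2-yl, or a plain phenyl, would read at this same place on the ring with two nitrogens. Also open, as far as these compounds go, is whether the swap would remain as quiet on a core carrying an amine or a carboxylic acid in place of the methoxy groups.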